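Methoxy for hydrogen on the phenyl ring of compound 3

The compounds below may be only part of what the source reports. "The series", "measured", "known", "first", "only" and "open" are said of these compounds alone.

Measured compounds:
Compound 1, `CC(=O)N1N=C(c2ccco2)CC1c1ccc(Br)cc1`: in a functional assay on HEp-2 cells (Homo sapiens) for cytotoxicity, read by sulforhodamine B assay, with a stated time of 48 h (a lower number here means a stronger inhibitor, a higher number a weaker inhibitor), compound 1 gives 51200 nM.
Compound 2, `COc1ccc(C2CC(c3ccco3)=NN2C(C)=O)cc1`: in this assay compound 2 gives 15600 nM.
Compound 3, `O=CCN1N=C(c2ccc3ccccc3c2)CC1c1ccccc1`: in this assay compound 3 gives 8400 nM.

Compound 3 has the lowest number of the three; its gap to compound 2 lies within the scatter, while its gap to compound 1 lies beyond it. Compound 4, `COc1ccc(C2CC(c3ccc4ccccc4c3)=NN2CC=O)cc1`, differs from compound 3 by methoxy in place of hydrogen on an aromatic carbon, on an aromatic carbon of a six-membered aromatic ring of carbon only, para to a large group.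

Among the compounds with values here, only one measured step touches a methoxy at this place: a 3.3-fold lower number from compound 1 to compound 2 (0.52 log units; beyond the scatter). That step swaps bromo for methoxy, not hydrogen for methoxy, so it bears on compound 4 only loosely, and the effect of a methoxy against a bare hydrogen is not shown anywhere here. A small gain is therefore expected, with the step of a 1.7-fold lower number from compound 3 to compound 4 (0.23 log units; within the scatter) likely near the edge of the scatter. For compound 4 in this assay the estimate is 5000 nM, with a range from 2000 nM to 15000 nM.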

Compound 4, half-maximal inhibitory concentration: 3230 nM
The estimate for compound 4 lay 1.5-fold (0.19 log units) above the measured number, within the range that was stated.
By their numbers in this assay, from the lowest: compound 4; then compounds 3 and 2 (each within the scatter of the next); then compound 1.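

In this assay, the change from phenyl to 4-methoxyphenyl gives a 2.6-fold lower number from compound 3 to compound 4 (0.42 log units; beyond the scatter), so methoxy is now compared directly with a bare hydrogen at this position. Within the data shown here, the only earlier step at this place, a 3.3-fold lower number from compound 1 to compound 2 (0.52 log units; beyond the scatter), compared methoxy with bromo on a different core and so could not show whether methoxy itself lowers the number or bromo raises it. Both steps now run towards a lower number with methoxy in the entering position, on two different cores, and no compound shown goes against this. No data given here account for the size or direction of the new step. From the compounds shown here alone, how an amine, a carboxylic acid or an ethoxy group on this aromatic carbon would compare with methoxy stays open, as does the effect of methoxy in place of hydrogen on the core of compound 2.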